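Lengthening the fatty chain of a pyrrolidine amide

The source may report more compounds than this note shows. Statements on the series, on what has been measured and on what is new or still open speak of the compounds shown alone.

Measured compounds:
compound 1, `CCCCCCCCCCCCCCCC(=O)N1CCCC1`, 4.6 ug/mL
compound 2, `CCCCCCCCCCCCCCCC(=O)N1CCOCC1`, 15.4 ug/mL

In a functional assay on MCF7 cells (Homo sapiens) for antiproliferative activity, read by sulforhodamine B assay, with a stated time of 48 h (on this read-out lower numbers stand for stronger inhibition of growth and higher numbers for weaker inhibition of growth), compound 1 gives 4.6 ug/mL, the lowest of the two numbers shown. Among the compounds with values here, the only measured step, a 3.3-fold higher number from compound 1 to compound 2 (0.52 log units; beyond the scatter), concerns the amine on the carbonyl carbon and not the chain. Compound 3, `CCCCCCCCCCCCCCCCCC(=O)N1CCCC1`, differs from compound 1 by ethyl in place of hydrogen on a saturated chain carbon, ten or more bonds along the chain from a carbonyl carbon. Within the data shown here, no measured step bears on that change, so the expectation rests on compound 1 alone: compound 3 is expected to show no step beyond the scatter, no change at the digits printed from compound 1 to compound 3 (within the scatter). The estimate for compound 3 is 4.6 ug/mL, within 2 ug/mL to 12 ug/mL.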

Compound 3, concentration for 50% growth inhibition: 7.4 ug/mL
Estimate against measurement, compound 3: 1.6-fold (0.21 log units) below; low and high end bracket the measured number.
By their numbers in this assay, from the lowest: compounds 1 and 3 (each within the scatter of the next); then compound 2.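

In this assay, ethyl in place of hydrogen on a saturated chain carbon, ten or more bonds along the chain from a carbonyl carbon, gives a 1.6-fold higher number from compound 1 to compound 3 (0.21 log units; within the scatter). Within the data shown here, this position on the chain therefore takes the added ethyl with no step beyond the scatter, while the only earlier step concerned the amine on the carbonyl carbon. No measured evidence offers a reason for this result.

Going by these compounds, whether a longer chain, or an amine or a carboxylic acid at this same position, would also stay within the scatter of compound 1 remains open. Also open, on these data alone, is whether the added ethyl would behave the same way on the morpholin-4-yl amide, compound 2.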